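This account rests on a few compounds, and the source may have more. Where it says the series, first, only, none or still open, it means among the compounds named here.

Three compounds have so far been measured in a toxicity assay on L02 cells (Homo sapiens) for inhibition, read by CCK-8 assay, with a stated time of 72 h, tested at 20 uM; on this read-out higher numbers stand for more inhibition of growth at the one concentration tested and lower numbers for less inhibition of growth:

Compound 1, `CC(C)(C)OC(=O)/C=C1/C(=O)Nc2ccccc21`: 64.1%
Compound 2, `COc1ccc2c(c1)/C(=C\C(=O)OC(C)(C)C)C(=O)N2`: 63.7%
Compound 3, `COc1ccc2c(c1)NC(=O)/C2=C/C(=O)OC(C)(C)C`: 63.6%

Compound 1 gives the largest of these three figures, but neither of the other two is set apart from it beyond the scatter: a number 0.4 percentage points lower from compound 1 to compound 2 (within the scatter), and a number 0.5 percentage points lower from compound 1 to compound 3 (within the scatter). Both of those steps put a methoxy group onto an aromatic carbon of the shared core, at two different positions, and neither moved the read-out in this assay by more than the scatter.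

Compound 4, `COc1cccc2c1NC(=O)/C2=C/C(=O)OC(C)(C)C`, is the third member of this series: methoxy in place of hydrogen on an aromatic carbon, the new group sitting ortho to a fused ring. The two measured methoxy steps are the only ones that bear on it, and both were flat, so no step beyond the scatter is expected here either; the expected step is a number 1.1 percentage points lower from compound 1 to compound 4 (within the scatter). Compound 4 is therefore estimated at 63% in this assay, with a range from 53% to 73%.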

Compound 4, percent growth inhibition at one concentration: 61.6%
For compound 4 the middle estimate is 1.4 percentage points above the measured one, within the range that was stated.
By their numbers in this assay, from the lowest: compounds 4, 3, 2 and 1 (each within the scatter of the next).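

With the methoxy group ortho to a fused ring, the change again stays small in this assay: the step is a number 2.5 percentage points lower from compound 1 to compound 4 (within the scatter). This position therefore joins the two tested earlier, and among the compounds shown, methoxy in place of hydrogen on an aromatic carbon gives no step beyond the scatter at any of the three positions. Nothing available here bears on why this position behaves as the other two do.

The compounds shown leave open whether a group other than methoxy, such as an amine, a chlorine atom or a longer alkoxy chain, would behave the same way at this position. They also leave open how this assay would respond if the tert-butyl ester shared by all four compounds gave way to a carboxylic acid.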